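Hydroxy for methoxy on the shared core

A few compounds are considered here, and "the series" means these few. Any claim that something is new, unique, unknown or untested is made for them only; others in the source may bear on it.

In a functional assay on OVCAR-3 cells (Homo sapiens) for inhibition, read by sulforhodamine B assay, with a stated time of 48 h (a higher number here means a weaker inhibitor of growth, a lower number a stronger inhibitor of growth), compound 2 `COc1ccc(/C=N/NC(=S)NC(C)(C)[C@H]2CC=C(C)CC2)cc1` gives 21200 nM. Going by the values given here, its only neighbour, compound 1 `CC1=CC[C@H](C(C)(C)NC(=S)N/N=C/c2ccccc2)CC1`, gives 20600 nM in this assay, and the step of a 1.0-fold higher number from compound 1 to compound 2 (0.01 log units; within the scatter) lies within the scatter, so compound 2 is not set apart from compound 1. Compound 3 `CC1=CC[C@H](C(C)(C)NC(=S)N/N=C/c2ccc(O)cc2)CC1` differs from compound 2 by hydrogen in place of methyl on an oxygen on an aromatic ring, methoxy to hydroxy, 4-methoxyphenyl to 4-hydroxyphenyl. Among the compounds with values here, no measured step removes the methyl from this oxygen; the one step touching this aromatic position, a 1.0-fold higher number from compound 1 to compound 2 (0.01 log units; within the scatter), was within the scatter. The step of a 1.0-fold lower number from compound 2 to compound 3 (0.00 log units; within the scatter) is therefore expected to stay within the scatter. Compound 3 is estimated at 21000 nM, range 10000 nM to 45000 nM.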

Compound 3, concentration for total growth inhibition: > 100000 nM
Compound 3 was reported as a limit; the forecaster's own chance of this, stated with the estimate: 10%; middle value at least 4.7-fold (0.67 log units) from the limit.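

Compound 3 stands as a limit and not a number in this assay: the limit of > 100000 nM in this assay, at which 1 of the 3 values shown sits. The step of an at least 4.7-fold higher number from compound 2 to compound 3 (0.67 log units; beyond the scatter) and the step of an at least 4.8-fold higher number from compound 1 to compound 3 (0.68 log units; beyond the scatter) are the only ones shown at this aromatic position that pass the scatter. This position is therefore not indifferent to its group: hydroxy sets compound 3 apart, while methoxy and hydrogen stay within the scatter of each other.

The limit leaves the full size of both steps unread. On these data alone, whether an amine or a carboxylic acid here would track hydroxy or stay with methoxy and hydrogen remains open.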